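This account rests on a few compounds, and the source may have more. Where it says the series, first, only, none or still open, it means among the compounds named here.

Compound 1 `COc1ccc(N2C(=O)COc3ccc(-c4cnc(Cl)c(NS(=O)(=O)c5ccc(F)cc5)c4)cc32)cc1` carries a 4-methoxyphenyl on the shared core, and in a functional assay on MCF7 cells (Homo sapiens) for antiproliferative activity, read by MTT assay, with a stated time of 72 h (on this read-out higher numbers stand for weaker inhibition and lower numbers for stronger inhibition), compound 1 gives 36000 nM. Compound 2 `O=C1COc2ccc(-c3cnc(Cl)c(NS(=O)(=O)c4ccc(F)cc4)c3)cc2N1c1ccc(F)cc1` differs from it by fluoro in place of methoxy on an aromatic carbon and in this assay compound 2 gives 32600 nM; the resulting step is a 1.1-fold lower number from compound 1 to compound 2 (0.04 log units; within the scatter).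

Compound 3 `COc1ccc(N2C(=O)COc3ccc(-c4cnc5ccccc5c4)cc32)cc1` has a different core; how the two cores differ is not broken down here. In this assay compound 3 reaches only a limit, > 40000 nM, as noted in the limit of > 40000 nM in this assay, at which 1 of the 3 values shown sits.

Compound 4 `O=C1COc2ccc(-c3cnc4ccccc4c3)cc2N1c1ccc(F)cc1` is to be measured and differs from compound 3 by fluoro in place of methoxy on an aromatic carbon, the same change that separates compound 1 from compound 2. The step to compound 4 is expected to be small, a step that the limit leaves unreadable from compound 3 to compound 4, resting on the measured step of a 1.1-fold lower number from compound 1 to compound 2 (0.04 log units; within the scatter). Since compound 3 sits at a limit, compound 4 is expected near 45000 nM, between 25000 nM and 90000 nM, and may again return only a limit.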

Compound 4, half-maximal inhibitory concentration: > 40000 nM
Compound 4 ended at the assay's limit; the forecaster's own chance of this, stated with the estimate: 60%; the middle value does not contradict the limit.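

No step can be read from compound 3 to compound 4, as each returns only a limit: the limit of > 40000 nM in this assay, at which 2 of the 4 values shown sit.

The compounds shown leave open whether fluoro in place of methoxy changes anything on the core of compound 3.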